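A Second Hydroxymethyl on the Shared Core

The source may report more compounds than this note shows. Statements on the series, on what has been measured and on what is new or still open speak of the compounds shown alone.

Compound 1 `COC(=O)c1cc2n(c1C)[C@@H](c1ccccc1)SC2`: 30600 nM
Compound 2 `Cc1c(CO)cc2n1[C@@H](c1ccccc1)SC2`: 1900 nM
Compound 3 `Cc1c(COC(=O)NCc2ccccc2)cc2n1[C@@H](c1ccccc1)SC2`: 1900 nM

All three were tested in a functional assay on MCF7 cells (Homo sapiens) for cytotoxicity, read by MTT assay, with a stated time of 96 h; on this read-out lower numbers stand for stronger inhibition and higher numbers for weaker inhibition. Compound 2 gives 1900 nM, which is level with compound 3 at the digits shown, and the two together give the lowest numbers of the set. Going by the values given here, the one step measured so far is a 16-fold lower number from compound 1 to compound 2 (1.21 log units; beyond the scatter), so swapping a methoxycarbonyl for a hydroxymethyl on the core made a large difference. Compound 2 and compound 3 show that capping that hydroxymethyl as a carbamate leaves the number unchanged within the scatter.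

Compound 4 `Cc1c(CO)c(CO)c2n1[C@@H](c1ccccc1)SC2` differs from compound 2 by hydroxymethyl in place of hydrogen on an aromatic carbon; the new group sits next to the ring atom that bears a hydroxymethyl group. Among the compounds with values here, no measured step adds a group to a bare ring hydrogen, so the only guides are that compound 2 already carries a hydroxymethyl and that the hydroxymethyl region tolerated extension in compound 3. A step of about a 1.3-fold higher number from compound 2 to compound 4 (0.12 log units; within the scatter) is expected, meaning no change beyond the scatter. Compound 4 is therefore estimated at 2500 nM, within a range of 800 nM to 8000 nM.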

Compound 4, half-maximal inhibitory concentration: 600 nM
Beside the measured number, compound 4's estimate is 4.2-fold (0.62 log units) above it, and the stated range ends above it.
By their numbers in this assay, from the lowest: compound 4; then compounds 2 and 3 (each within the scatter of the next); then compound 1.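

In this assay, hydroxymethyl in place of hydrogen on this aromatic carbon gives a 3.2-fold lower number from compound 2 to compound 4 (0.50 log units; beyond the scatter), a modest step but one that lies beyond the scatter. Going by these compounds alone, the earlier compounds varied only the group on the ring atom that bears the hydroxymethyl in compound 2, so this is the first sign that a second atom of the five-membered aromatic ring also affects the number, and that the hydrogen there can be replaced without losing activity in this assay. Nothing shown here explains why this one change lowers the number.

The compounds shown leave open whether the gain depends on the hydroxymethyl itself or would also come with another group on this carbon, such as a plain methyl, a methoxymethyl, an aminomethyl or a carboxylic acid. They also leave open whether the new hydroxymethyl can be capped as a carbamate, as the hydroxymethyl of compound 2 is in compound 3, and whether a longer chain such as hydroxyethyl would fit on this carbon.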